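From benzyl to phenylsulfonyl on the shared core

This account rests on a few compounds, and the source may have more. Where it says the series, first, only, none or still open, it means among the compounds named here.

The values so far in a functional assay on KB cells (Homo sapiens) for cytotoxicity (on this read-out lower numbers stand for stronger inhibition and higher numbers for weaker inhibition), are these:
- compound 1 `COc1ccc(S(=O)(=O)N2CCc3cccc(NS(=O)(=O)c4ccc(F)cc4)c32)cc1` gives 1200 nM as measured
- compound 2 `COc1ccc(S(=O)(=O)N2CCc3cccc(NC(=O)c4cccs4)c32)cc1` gives 47 nM as measured
- compound 3 `COc1ccc(S(=O)(=O)N2CCc3cccc(NCc4ccccc4)c32)cc1` gives > 10000 nM as a limit

Compound 3 stands at the weak end of these three, and its steps to both others lie beyond the scatter. For compound 3 the entry of > 10000 nM is a limit of the assay and not a number.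

The next compound is compound 4 `COc1ccc(S(=O)(=O)N2CCc3cccc(NS(=O)(=O)c4ccccc4)c32)cc1` which carries phenylsulfonyl in place of benzyl on a nitrogen on an aromatic ring. The closest measured change is benzyl in place of (4-fluorophenyl)sulfonyl, which gave an at least 8.3-fold higher number from compound 1 to compound 3 (0.92 log units; beyond the scatter) and runs opposite to the change now in view. The step of an at least 210-fold higher number from compound 2 to compound 3 (2.32 log units; beyond the scatter) involves a carbonyl group instead, so it bears less directly, though it too is large and leads to the higher number. A step of at least modest size towards a lower number is therefore expected in this assay for this change. The estimate amounts to an expected at least 10-fold lower number from compound 3 to compound 4 (1.00 log units; beyond the scatter) on this read-out. Compound 4 is estimated at 1000 nM with an expected range from 300 nM to 4000 nM in all.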

Compound 4, half-maximal inhibitory concentration: 650 nM
Compound 4: middle estimate off by 1.5-fold (0.19 log units), on the high side; measured number inside the range.
By their numbers in this assay, from the lowest: compound 2; then compounds 4 and 1 (each within the scatter of the next). At a limit, above all of these: compound 3.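

In this assay, phenylsulfonyl in place of benzyl on this nitrogen gives an at least 15-fold lower number from compound 3 to compound 4 (1.18 log units; beyond the scatter), so this sulfonyl group brings the compound back from the limit without any fluoro on its ring. Compound 3 stands at a limit of the assay, so the step gives only a lower bound on the change: the limit of > 10000 nM in this assay, at which 1 of the 4 values shown sits. Hydrogen in place of fluoro on the aromatic carbon gives a 1.8-fold lower number from compound 1 to compound 4 (0.27 log units; within the scatter), which leaves the two sulfonyl compounds indistinguishable, whereas phenylsulfonyl in place of (thiophen-2-yl)carbonyl gives a 14-fold higher number from compound 2 to compound 4 (1.14 log units; beyond the scatter), so the plain sulfonyl compound still falls well short of the thiophene carbonyl compound.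

The compounds shown do not separate the part played by the carbonyl link from that of the thiophene ring, and a benzoyl group or a (thiophen-2-yl)sulfonyl group on this nitrogen would pull the two apart. Also open, going by these compounds, is how the free amine, or a methoxy or chloro group in place of the fluoro on the phenylsulfonyl ring, would read in this assay.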